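This account rests on a few compounds, and the source may have more. Where it says the series, first, only, none or still open, it means among the compounds named here.

Compound 1: `O=S(=O)(NCCCNCc1cccc(Cl)c1)c1cc(C(F)(F)F)cc(C(F)(F)F)c1` — 2200 nM
Compound 2: `O=S(=O)(NCCNCc1cccc2ccccc12)c1cc(C(F)(F)F)cc(C(F)(F)F)c1` — 21000 nM

In a functional assay on A2780 cells (Homo sapiens) for inhibition, read by MTT assay, with a stated time of 72 h (a higher number here means a weaker inhibitor of growth, a lower number a stronger inhibitor of growth), compound 1 holds the lowest of the two numbers measured, and compound 2 gives a number well beyond the scatter above it. Compound 3, `COc1ccccc1CNCCCNS(=O)(=O)c1cc(C(F)(F)F)cc(C(F)(F)F)c1`, has not yet been tested. It differs from compound 1 by 2-methoxyphenyl in place of 3-chlorophenyl on a saturated chain carbon bound to an amine nitrogen. Among the compounds with values here, no measured pair shows this change alone, so its size is open; a modest weakening, at or just beyond the scatter, is expected, as a 1.6-fold higher number from compound 1 to compound 3 (0.20 log units; within the scatter). Compound 3 is therefore estimated at 3500 nM, within a range of 1200 nM to 10000 nM.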

Compound 3, concentration for 50% growth inhibition: 1500 nM
Compound 3: the middle estimate sits 2.3-fold (0.37 log units) above what was measured; measured number inside the range.
By their numbers in this assay, from the lowest: compounds 3 and 1 (each within the scatter of the next); then compound 2.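

In this assay, 2-methoxyphenyl in place of 3-chlorophenyl on a saturated chain carbon bound to an amine nitrogen gives a 1.5-fold lower number from compound 1 to compound 3 (0.17 log units; within the scatter). This first step at the position shows that the exchange, which brings in one hydrogen-bond acceptor, leaves the number within the scatter. No measurement shown here bears on why the two compounds read alike.

On these data alone, what a longer chain or a carboxylic acid on this ring would do stays open. Compound 2 differs from compound 1 in more than one place, so it cannot settle this.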